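Fluoro to tert-butyl on the piperidine

A few compounds are considered here, and "the series" means these few. Any claim that something is new, unique, unknown or untested is made for them only; others in the source may bear on it.

For the measured compounds named here, in a functional assay on MEF cells (Mus musculus) for antiproliferative activity, read by luminescence, with a stated time of 16 h (on this read-out lower numbers stand for an effect already at smaller amounts and higher numbers for an effect only at larger amounts of compound), compound 1 `O=C(Nc1ccc(S(=O)(=O)N2CCC(F)CC2)cc1)c1ccc([N+](=O)[O-])o1` gives 17500 nM, the highest of the three numbers so far. Compound 2 `O=C(Nc1ccc(S(=O)(=O)N2CCC(Cl)CC2)cc1)c1ccc([N+](=O)[O-])o1` gives 4800 nM, and compound 3 `CC1CCN(S(=O)(=O)c2ccc(NC(=O)c3ccc([N+](=O)[O-])o3)cc2)CC1` gives 4600 nM. Compound 4 `CC(C)(C)C1CCN(S(=O)(=O)c2ccc(NC(=O)c3ccc([N+](=O)[O-])o3)cc2)CC1` carries tert-butyl in place of fluoro on a saturated ring carbon. Two measured replacements of the same fluoro bear on this change: chloro gives a 3.6-fold lower number from compound 1 to compound 2 (0.56 log units; beyond the scatter), and methyl gives a 3.8-fold lower number from compound 1 to compound 3 (0.58 log units; beyond the scatter). Both are modest, while a 1.0-fold lower number from compound 2 to compound 3 (0.02 log units; within the scatter) stays within the scatter. Going by the values given here, a modest step in the same direction is therefore expected, but no tert-butyl compound has been measured, so the range stays wide. The estimated step is a 4.4-fold lower number from compound 1 to compound 4 (0.64 log units; beyond the scatter). For compound 4 the expected value is 4000 nM, with an estimated range of 1300 nM to 12000 nM.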

Compound 4, half-maximal effective concentration: 1400 nM
Estimate against measurement, compound 4: 2.9-fold (0.46 log units) above; low and high end bracket the measured number.
By their numbers in this assay, from the lowest: compound 4; then compounds 3 and 2 (each within the scatter of the next); then compound 1.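

In this assay, tert-butyl goes further than any earlier replacement of fluoro on this saturated ring carbon, with a 13-fold lower number from compound 1 to compound 4 (1.10 log units; beyond the scatter). It also separates itself from the two groups that could not be told apart, with a 3.3-fold lower number from compound 3 to compound 4 (0.52 log units; beyond the scatter) and a 3.4-fold lower number from compound 2 to compound 4 (0.54 log units; beyond the scatter), so this position allows a further drop beyond the values of compounds 2 and 3. No measurement shown accounts for this drop. As far as these compounds go, whether a longer chain, an amine or a carboxylic acid at this ring carbon would lower the number further stays open.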